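The source may hold more compounds than are shown below. What is called first, only, known or untested is meant among the compounds shown, and "the series" means these compounds.

Compound 1 `CCN(CC)C(=O)CC1CCc2cc(OC)c(OC)cc21` stands highest of the two measured compounds in a functional assay on the whole organism (strain Wistar) for inhibition, with Rattus norvegicus as the target, read by paw edema, with stated times of 60 min and 2 h, at a dose of 100 mg/kg by the oral route (on this read-out higher numbers stand for more inhibition at the one dose given (going by the name of the read-out) and lower numbers for less inhibition), where compound 1 gives 40%. Compound 2 `CCCCNC(=O)CC1CCc2cc(OC)c(OC)cc21` gives 24% in this assay, which is a number 16 percentage points lower from compound 1 to compound 2 (beyond the scatter), a change of butylamino in place of diethylamino on a carbonyl carbon. Compound 3 `CCCCCCNC(=O)CC1CCc2cc(OC)c(OC)cc21` differs from compound 1 by hexylamino in place of diethylamino on a carbonyl carbon. Among the measured compounds shown here, only the step from compound 1 to compound 2 bears on this change, and it was modest and downward; the hexylamino of compound 3 is a change of the same kind. Compound 3 is therefore expected to show a number 18 percentage points lower from compound 1 to compound 3 (beyond the scatter), an estimated 22%, between 8% and 38%.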

Compound 3, a percentage reported as inhibition, in the whole organism at one dose (the size of the read-out at that dose, not a potency): 41.5%
For compound 3 the middle estimate is 19.5 percentage points below the measured one; measured number outside the range, above it.
By their numbers in this assay, from the lowest: compound 2; then compounds 1 and 3 (each within the scatter of the next).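

In this assay, hexylamino on this carbonyl carbon cannot be told apart from diethylamino, with a number 1.5 percentage points higher from compound 1 to compound 3 (within the scatter), so the lower number of compound 2 does not hold for every such replacement. The chain itself matters here, with a number 17.5 percentage points higher from compound 2 to compound 3 (beyond the scatter) for the added ethyl. Nothing available explains this dependence on chain length. The compounds shown leave open whether an octylamino chain would give a higher or lower number than hexylamino, and how a piperidine amide would compare with diethylamino.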